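This account rests on a few compounds, and the source may have more. Where it says the series, first, only, none or still open, it means among the compounds named here.

Two measured compounds set the scene. Compound 1, `CCC1C(=O)N(C)c2cnc(-n3ccc4cc(C(N)=O)ccc43)nc2N1c1ccn(C)n1`, and compound 2, `CC[C@@H]1C(=O)N(C)c2cnc(Nc3ccc(S(=O)(=O)NCCO)cc3)nc2N1C1CCCC1`, share a core but differ widely elsewhere. In a functional assay on HeLa cells (Homo sapiens) for antiproliferative activity, read by CCK-8 assay, with a stated time of 72 h (a higher number here means a weaker inhibitor of growth, a lower number a stronger inhibitor of growth), compound 1 gives 27400 nM, while in this assay compound 2 gives 459 nM, the lower of the two numbers and therefore the stronger growth inhibitor; the gap between them lies well beyond the ordinary scatter of the measurement.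

The next compound, compound 3, `CC[C@@H]1C(=O)N(C)c2cnc(Nc3ccc(S(N)(=O)=O)cc3)nc2N1C1CCCC1`, is built from compound 2 by a single small change: hydrogen in place of 2-hydroxyethyl on a sulfonamide nitrogen. The rest of the molecule stays untouched. Among the compounds with values here, no measured pair here shows what such a change does, so the expectation rests on its small size alone. For compound 3 the step of a 1.1-fold lower number from compound 2 to compound 3 (0.04 log units; within the scatter) is expected to stay within the scatter, with no clear direction. Compound 3 is therefore estimated at 420 nM, most likely between 150 nM and 1200 nM.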

Compound 3, concentration for 50% growth inhibition: 317 nM
Compound 3: middle estimate off by 1.3-fold (0.12 log units), on the high side; low and high end bracket the measured number.
By their numbers in this assay, from the lowest: compounds 3 and 2 (each within the scatter of the next); then compound 1.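

Replacing the 2-hydroxyethyl on the sulfonamide nitrogen with hydrogen, which turns a (2-hydroxyethyl)sulfamoyl into a plain sulfamoyl, gives a 1.4-fold lower number from compound 2 to compound 3 (0.16 log units; within the scatter) in this assay. This pair therefore shows that, with the rest of the molecule unchanged, this assay cannot tell the two compounds apart, so the 2-hydroxyethyl chain is not required for the growth inhibition seen with compound 2. No measurement at hand offers an explanation for this result.

As far as these compounds go, it remains open whether a different group on the same nitrogen, such as a methyl, a longer chain ending in an amine, or one ending in a carboxylic acid, would also leave the number within the scatter. From the compounds shown here alone, it is equally open whether this swap would read the same way with another part of the molecule changed.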